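The compounds below may be only part of what the source reports. "The series", "measured", "known", "first", "only" and "open" are said of these compounds alone.

Measured so far: compound 1 `COCCC(=O)N[C@@H]1CC[C@@H](Nc2ncc3c(Br)nn(-c4ccc5ncccc5c4)c3n2)C1`, 159 nM; compound 3 `Brc1nn(-c2ccc3ncccc3c2)c2nc(N[C@@H]3CC[C@@H](c4ncc[nH]4)C3)ncc12`, 545 nM; compound 2 `COCc1noc([C@@H]2CC[C@@H](Nc3ncc4c(Br)nn(-c5ccc6ncccc6c5)c4n3)C2)n1`, "nd" (no result reported).

In an assay on SK-OV-3 cells for inhibition of eIF-2-alpha kinase GCN2 (Homo sapiens) (a lower number here means a stronger inhibitor, a higher number a weaker inhibitor), compound 3 gives 545 nM, the highest of the two numbers available. Its nearest neighbour is compound 1 with 159 nM, and compound 2 has no result in this assay. Compound 4 `COCCS(=O)(=O)N[C@@H]1CC[C@@H](Nc2ncc3c(Br)nn(-c4ccc5ncccc5c4)c3n2)C1` differs from compound 3 by ((2-methoxyethyl)sulfonyl)amino in place of 1H-imidazol-2-yl on a saturated ring carbon. For the measured compounds named here, one measured step bears on this change: a 3.4-fold higher number from compound 1 to compound 3 (0.53 log units; beyond the scatter). Going by the values given here, there the group that entered is the one that now leaves, and the group that now enters is a close relative of the one in compound 1. That step is therefore expected to run back in the opposite direction with a similar size. Compound 4 is expected to give about 200 nM, within 80 nM to 500 nM. This amounts to an expected step of a 2.7-fold lower number from compound 3 to compound 4 (0.44 log units; beyond the scatter).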

Compound 4, half-maximal inhibitory concentration: 262 nM
Compound 4: the middle estimate sits 1.3-fold (0.12 log units) below what was measured; low and high end bracket the measured number.
By their numbers in this assay, from the lowest: compounds 1 and 4 (each within the scatter of the next); then compound 3.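

In this assay putting ((2-methoxyethyl)sulfonyl)amino in place of 1H-imidazol-2-yl on the saturated ring carbon gives a 2.1-fold lower number from compound 3 to compound 4 (0.32 log units; beyond the scatter) and so repeats, with a second chain, the advantage over the ring seen earlier. Exchanging (2-methoxyethyl)carbonyl for (2-methoxyethyl)sulfonyl on the amine nitrogen gives a 1.6-fold higher number from compound 1 to compound 4 (0.22 log units; within the scatter) and so shows no real difference between these two groups here. Nothing measured explains either result.

On these data alone, whether a plain amine or a carboxylic acid on this ring carbon would fit as well remains open. So does the effect of a longer chain on the sulfonyl group.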